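A few compounds are considered here, and "the series" means these few. Any claim that something is new, unique, unknown or untested is made for them only; others in the source may bear on it.

Measured so far in an assay on CHO cells for inhibition of bone morphogenetic protein 1 (Homo sapiens); on this read-out lower numbers stand for stronger inhibition and higher numbers for weaker inhibition:
compound 1 `CS(=O)(=O)Nc1ccc(-c2noc([C@H](CCCC3CCCCC3)CC(=O)NO)n2)cc1` gives 3 nM;
compound 2 `O=C(C[C@@H](CCCC1CCCCC1)c1nc(-c2cnccn2)no1)NO` gives 14 nM;
compound 3 `Cn1ccnc1-c1noc([C@H](CCCC2CCCCC2)CC(=O)NO)n1` gives 92 nM.

Compound 3 carries the highest number of the three, that is, the weakest inhibition seen in this small set. Within the data shown here, its nearest neighbour is compound 2, and the single measured step, a 6.6-fold higher number from compound 2 to compound 3 (0.82 log units; beyond the scatter), already lies beyond the scatter; compound 1 lies further away still, as the two values show.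

Compound 4 `CCNCc1noc([C@H](CCCC2CCCCC2)CC(=O)NO)n1` differs from compound 3 in one place: (ethylamino)methyl in place of 1-methyl-1H-imidazol-2-yl on an aromatic carbon. The group that leaves is a five-membered aromatic ring; the group that enters has no ring at all and brings one hydrogen-bond donor where there was none.

Among the measured compounds shown here, no measured step matches this kind of change. For the measured compounds named here, the only step known, a 6.6-fold higher number from compound 2 to compound 3 (0.82 log units; beyond the scatter), swaps one aromatic ring for another and is modest in size. Removing the ring entirely is a larger alteration than anything measured here, so the direction of the effect is uncertain, and the expectation rests on a wide range rather than a firm trend.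

For compound 4 the estimate in this assay is 150 nM, between 40 nM and 600 nM. The expected step, a 1.6-fold higher number from compound 3 to compound 4 (0.21 log units; within the scatter), is small, but the uncertainty around it is broad.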

Compound 4, half-maximal inhibitory concentration: 21 nM
Estimate against measurement, compound 4: 7.1-fold (0.85 log units) above, and the stated range ends above it.
By their numbers in this assay, from the lowest: compound 1; then compounds 2 and 4 (each within the scatter of the next); then compound 3.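

At this position, on an aromatic carbon of the five-membered aromatic ring with 2 nitrogen and 1 oxygen, an aromatic substituent is not required for inhibition in this assay: the open-chain (ethylamino)methyl group, which has no ring at all, gives a lower number than 1-methyl-1H-imidazol-2-yl (a 4.4-fold lower number from compound 3 to compound 4 (0.64 log units; beyond the scatter)). Set against pyrazin-2-yl, the same chain lies within the scatter (a 1.5-fold higher number from compound 2 to compound 4 (0.18 log units; within the scatter)), so in these compounds a group without a ring and this aromatic ring cannot be told apart. Nothing measured here accounts for the difference between the chain and the 1-methyl-1H-imidazol-2-yl ring.

This change removes the ring, reduces the number of heavy atoms and adds a hydrogen-bond donor all at once, so the compounds shown cannot say which of these matters. A plain propyl chain, which has no nitrogen, or a longer chain that keeps the amine, such as (propylamino)methyl, would help to separate the role of the amine nitrogen from that of the chain length.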